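Swapping hydroxy for fluoro in compound 1

The compounds below may be only part of what the source reports. "The series", "measured", "known", "first", "only" and "open" are said of these compounds alone.

- compound 1 `COc1cc(OC)c2sc(-c3ccc(N/C=C\C(=O)c4ccc(OC)c(O)c4)c(C)c3)nc2c1`: 16100 nM
- compound 2 `COc1ccc(C(=O)/C=C\Nc2ccc(-c3nc4cc(OC)c(OC)c(OC)c4s3)cc2C)cc1O`: 11400 nM
- compound 3 `COc1cc(OC)c2sc(-c3ccc(N/C=C\C(=O)c4ccc(OC)c(O)c4)cc3)nc2c1`: 12100 nM

All three values come from a functional assay on HeLa cells (Homo sapiens) for antiproliferative activity, read by sulforhodamine B assay, with a stated time of 48 h; a higher number here means a weaker inhibitor, a lower number a stronger inhibitor. Compound 1 stands level with its two neighbours: there is a 1.4-fold lower number from compound 1 to compound 2 (0.15 log units; within the scatter) and a 1.3-fold lower number from compound 1 to compound 3 (0.12 log units; within the scatter). The unmeasured compound 4 `COc1cc(OC)c2sc(-c3ccc(N/C=C\C(=O)c4ccc(OC)c(F)c4)c(C)c3)nc2c1` carries a different change: fluoro in place of hydroxy on an aromatic carbon. Here fluoro takes the place of hydroxy on an aromatic carbon, turning 3-hydroxy-4-methoxyphenyl into 3-fluoro-4-methoxyphenyl. Among the compounds with values here, both measured steps changed other groups, so they bear on this one only indirectly, and no measured compound tests the hydroxy itself. No direction can therefore be expected, and the estimated step stays within the scatter: a 1.0-fold lower number from compound 1 to compound 4 (0.00 log units; within the scatter). For compound 4 the estimated value is 16000 nM, with an expected range from 6000 nM to 45000 nM.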

Compound 4, half-maximal inhibitory concentration: 14700 nM
Compound 4: middle estimate off by 1.1-fold (0.04 log units), on the high side; the measured number falls inside the stated range.
By their numbers in this assay, from the lowest: compounds 2, 3, 4 and 1 (each within the scatter of the next).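

Fluoro in place of hydroxy gives a 1.1-fold lower number from compound 1 to compound 4 (0.04 log units; within the scatter) in this assay, the first direct test of this position. Here the hydrogen-bond donor and acceptor counted for hydroxy are gone, yet compound 4 stays level with compound 1, so at these weak values this assay does not show that the hydroxy is needed. No measurement at hand explains this result. On these data alone, whether an amine or a carboxylic acid at this place would also stay level remains open, as does whether fluoro would do the same in compound 2 or compound 3.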